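Replacing the urea on the piperazine nitrogen with phenyl

The source may hold more compounds than are shown below. What is called first, only, known or untested is meant among the compounds shown, and "the series" means these compounds.

Within the data shown here, in a functional assay on cells (T-cell, Homo sapiens) for inhibition (on this read-out higher numbers stand for weaker inhibition and lower numbers for stronger inhibition), compound 1 `COc1ccc(-c2cnc3nc(N)nc(N4CCN(C(=O)Nc5ccc(C)cc5)CC4)c3n2)cc1OC` gives 0.8 nM, the only number measured in this set. Compound 2 `CCOc1nc(N)nc2ncc(-c3ccc(C#N)cc3)nc12` returns only a limit of the assay, > 10000 nM. Compound 3 `COc1ccc(-c2cnc3nc(N)nc(N4CCN(c5ccccc5)CC4)c3n2)cc1OC` differs from compound 1 in a single place: phenyl in place of (4-methylphenyl)carbamoyl on an amine nitrogen in a ring. Among the measured compounds shown here, no step between two measured compounds is available, so the direction rests on the change alone; a weakening of inhibition beyond the usual scatter is expected, with an estimated step of a 25-fold higher number from compound 1 to compound 3 (1.40 log units; beyond the scatter) in this assay. Compound 3 is accordingly estimated at 20 nM, between 3 nM and 200 nM.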

Compound 3, half-maximal inhibitory concentration: 400 nM
Compound 3: the middle estimate sits 20-fold (1.30 log units) below what was measured; measured number outside the range, above it.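

The step of a 500-fold higher number from compound 1 to compound 3 (2.70 log units; beyond the scatter) in this assay shows that inhibition at this amine nitrogen in a ring depends heavily on what is attached there. Phenyl keeps a six-membered aromatic ring of carbon only at this place, yet that ring alone does not retain the strength of compound 1. Nothing measured here accounts for this loss. The compounds shown leave open whether the carbamoyl link or the methyl matters more. A phenylcarbamoyl or a benzoyl group at this nitrogen would separate those parts.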